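A few compounds are considered here, and "the series" means these few. Any claim that something is new, unique, unknown or untested is made for them only; others in the source may bear on it.

In an ADME assay on microsomes from liver (Homo sapiens) for metabolic stability (on this read-out higher numbers stand for a longer-lived compound and lower numbers for a shorter-lived compound), compound 1 (`CCc1cccc2ccc(-c3ccc(C(/C=C4\OC(=O)NC4=O)(CC)CC)c(=O)[nH]3)cc12`) gives 0.178 h and compound 3 (`CCC(/C=C1\OC(=O)NC1=O)(CC)c1ccc(-c2ccc3cccc(F)c3c2)[nH]c1=O`) gives 0.948 h as the higher of the two actual numbers, a gap beyond the scatter. Compound 2 (`CC(C)[C@@H](c1ccc(-c2ccc3cccc(F)c3c2)[nH]c1=O)[C@@H]1OC(=O)NC1=O`) shows > 3 h as a limit, not a number.

Compound 4 (`CCC(/C=C1\OC(=O)NC1=O)(CC)c1ccc(-c2ccc3cccc(C(C)C)c3c2)[nH]c1=O`), not yet measured, differs from compound 3 in one place (isopropyl in place of fluoro on an aromatic carbon), with isopropyl in place of fluoro on an aromatic carbon. Among the measured compounds shown here, one measured step bears on this: a 5.3-fold higher number from compound 1 to compound 3 (0.73 log units; beyond the scatter) as fluoro replaced ethyl at that same place. Ethyl and isopropyl are both carbon chains, so going from fluoro back to a chain is expected to bring a fall of comparable size in this assay rather than a rise. That expectation rests on this single step and on compound 1 at 0.178 h as the closest value, which is thin support. The expected change is a 3.8-fold lower number from compound 3 to compound 4 (0.58 log units; beyond the scatter) and it carries real uncertainty. For compound 4 the estimated half-life is 0.25 h within an expected range of 0.08 h to 0.7 h on this reading.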

Compound 4, half-life: 0.758 h
The estimate for compound 4 lay 3.0-fold (0.48 log units) below the measured number; measured number outside the range, above it.
By their numbers in this assay, from the lowest: compound 1; then compounds 4 and 3 (each within the scatter of the next). At a limit, above all of these: compound 2.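

In this assay, isopropyl in place of fluoro on this aromatic carbon gives a 1.3-fold lower number from compound 3 to compound 4 (0.10 log units; within the scatter), so the half-life does not separate these two groups at this place, though one is a halogen and the other a branched carbon group. A carbon group here therefore does not by itself bring a short half-life. The ethyl and isopropyl groups do not behave alike. Methyl in place of hydrogen on the saturated chain carbon, which turns that ethyl into isopropyl, gives a 4.3-fold higher number from compound 1 to compound 4 (0.63 log units; beyond the scatter), so the earlier gap between ethyl and fluoro does not extend to every carbon group at this place.

Nothing shown explains why ethyl and isopropyl part here. From the compounds shown here alone, how an amine, a methoxy group or a longer chain would fare at this place stays open.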